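Fluorophenyl amine in place of oxanyl amine on the core

The compounds below may be only part of what the source reports. "The series", "measured", "known", "first", "only" and "open" are said of these compounds alone.

Measured compounds:
compound 1, `Cc1cc(-c2cnn3c(NCC4CCOCC4)nc(NC4CCOCC4)nc23)ccc1C(=O)NC1CC1`: 780 nM in a functional assay on OVCAR-3 cells (Homo sapiens) for antiproliferative activity; a higher number here means a weaker inhibitor of growth, a lower number a stronger inhibitor of growth
compound 2, `Cc1cc(-c2cnn3c(NCC4CCOCC4)nc(NC4CCCC4)nc23)ccc1NC(=O)C1CC1`: "not determined" (no result reported) in this assay

Within the data shown here, compound 1 is the only compound of this pair with a number; in this assay compound 1 gives 780 nM. Among the measured compounds shown here, for compound 2, whose structure stands beside it above, no result was reported in this assay, so it offers no comparison and no step between measured compounds exists here.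

Compound 3, `Cc1cc(-c2cnn3c(NCC4CCOCC4)nc(Nc4ccccc4F)nc23)ccc1C(=O)NC1CC1`, keeps the shared core and the amide side of compound 1 and differs from it in a single place: 2-fluorophenyl in place of oxan-4-yl on a nitrogen on an aromatic ring. For the measured compounds named here, since no measured pair shows what such a change does, the expectation rests on compound 1 alone and on the size of the change. The writer expects the step from compound 1 to compound 3 in this assay to be small and towards stronger growth inhibition, close to the edge of the usual scatter, that is a 2.0-fold lower number from compound 1 to compound 3 (0.29 log units; within the scatter). Compound 3 is therefore estimated at 400 nM, with a range from 100 nM to 1600 nM.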

Compound 3, concentration for 50% growth inhibition: 190 nM
Compound 3: middle estimate off by 2.1-fold (0.32 log units), on the high side, within the range that was stated.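

Read in this assay, replacing the (oxan-4-yl)amino group with a (2-fluorophenyl)amino group gives a 4.1-fold lower number from compound 1 to compound 3 (0.61 log units; beyond the scatter) and supplies the first step in this series that can be read. It shows that, on this nitrogen on an aromatic ring, a six-membered aromatic ring of carbon only, bearing fluorine, can stand in place of a non-aromatic ring with one hetero atom, and that growth inhibition grows stronger even though the hydrogen-bond acceptor of the oxan-4-yl group is gone. No measurement on these compounds accounts for this gain, so the step stands as an observation without an explanation.

This single step does not separate what the aromatic ring contributes from what the fluorine contributes, and a plain phenyl or a pyridinyl group on the same nitrogen would be needed to tell the two apart. Any step involving compound 2 cannot be read, so the compounds shown also leave open whether other groups at this position, or changes on the amide side, would move growth inhibition in the same direction.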